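Compound 3 to compound 4: a ring swap at the limit

The source may hold more compounds than are shown below. What is called first, only, known or untested is meant among the compounds shown, and "the series" means these compounds.

Compound 3 (`CCCCCCCCCCCCCCCCCCOP(=O)(O)OC[C@H]1O[C@@H](n2ccc3c(-c4ccccc4)ncnc32)[C@H](O)[C@@H]1O`) gives > 50000 nM in an ADME assay on BJ cells (Homo sapiens) for cytotoxicity, read by MTT assay, with a stated time of 72 h (on this read-out lower numbers stand for higher toxicity in this test and higher numbers for lower toxicity in this test), which is a limit of the assay and not a number. Its standing is therefore only this: the limit of > 50000 nM in this assay, at which 1 of the 3 values shown sits. Compound 4 (`CCCCCCCCCCCCCCCCCCOP(=O)(O)OC[C@H]1O[C@@H](n2ccc3c(-c4ccoc4)ncnc32)[C@H](O)[C@@H]1O`) has furan-3-yl in place of phenyl on an aromatic carbon.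

Going by the values given here, no measured step covers this swap directly. The nearest evidence comes from two compounds with five-membered aromatic rings at this carbon. In this assay compound 1 (`OC[C@H]1O[C@@H](n2cc(F)c3c(-c4ccsc4)ncnc32)[C@H](O)[C@@H]1O`) gives 620 nM and compound 2 (`OC[C@H]1O[C@@H](n2cc(F)c3c(-c4nccs4)ncnc32)[C@H](O)[C@@H]1O`) gives 630 nM. That step, a 1.0-fold higher number from compound 1 to compound 2 (0.01 log units; within the scatter), is a change between two five-membered rings and lies within the scatter. It does not involve phenyl, so it bears only weakly on the present swap.

A modest move toward lower numbers is expected, and another limit reading is about as likely. The expected change is an at least 1.4-fold lower number from compound 3 to compound 4 (0.15 log units; that floor lies within the scatter) as an estimate only. For compound 4 the estimated value is 35000 nM, with an expected range from 8000 nM to 70000 nM.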

Compound 4, half-maximal cytotoxic concentration: 44200 nM
For compound 4 the middle estimate is 1.3-fold (0.10 log units) below the measured one, and the stated range covers the measured number.
By their numbers in this assay, from the lowest: compounds 1 and 2 (each within the scatter of the next); then compound 4. At a limit, above all of these: compound 3.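

Furan-3-yl in place of phenyl on this aromatic carbon gives an at least 1.1-fold lower number from compound 3 to compound 4 (0.05 log units; that floor lies within the scatter) in this assay. Compound 4 reads as a number, so this core now has one value inside the range of the assay, and a five-membered aromatic ring with one oxygen can be placed on it. Compound 3 stands at a limit of the assay and not at a number, so the true size of the step stays unknown: the limit of > 50000 nM in this assay, at which 1 of the 4 values shown sits.

On these data alone, compound 1 and compound 2 differ from compound 4 in more than one place, so whether thiophen-3-yl or 1,3-thiazol-2-yl on this core would read like furan-3-yl remains open. Also open, as far as these compounds go, is how an amine on this aromatic carbon, or a shorter chain on the phosphate, would read in this assay.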